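A few compounds are considered here, and "the series" means these few. Any claim that something is new, unique, unknown or untested is made for them only; others in the source may bear on it.

Measured so far: compound 1 `CC/C(=C(/c1ccc(/C=C/C(=O)O)cc1)c1ccc2[nH]ncc2c1C)c1ccccc1`, 50 nM; compound 2 `CC/C(=C(/c1ccc(/C=C/C(=O)O)cc1)c1ccc2[nH]nc(Cl)c2c1)c1ccccc1`, 284 nM.

Compound 1 carries a 4-methyl-1H-indazol-5-yl group on a double-bonded chain carbon bound to an aromatic carbon and a double-bonded chain carbon, and in a functional assay on MCF7 cells (Homo sapiens) for cytotoxicity, read by CellTiter-Glo, with a stated time of 5 days (on this read-out higher numbers stand for weaker inhibition and lower numbers for stronger inhibition), compound 1 gives 50 nM. Among the measured compounds shown here, compound 2 has a 3-chloro-1H-indazol-5-yl group at that place, and in this assay compound 2 gives 284 nM; on these two numbers compound 2 stands at the higher one, the only measured step being a 5.7-fold higher number from compound 1 to compound 2 (0.75 log units; beyond the scatter).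

Compound 3 `CC/C(=C(/c1ccc(/C=C/C(=O)O)cc1)c1cc2cn[nH]c2cc1Cl)c1ccccc1` is built from compound 2 by rearranging the same atoms: 6-chloro-1H-indazol-5-yl in place of 3-chloro-1H-indazol-5-yl on a double-bonded chain carbon bound to an aromatic carbon and a double-bonded chain carbon. For the measured compounds named here, no measured step swaps the position of a chlorine on this ring system, so the single step from compound 1 to compound 2 bears on it only loosely, showing that a change of substitution on the shared core can shift the number modestly. The chlorine of compound 3 sits on the six-membered carbon ring of the indazole, as the methyl of compound 1 does, so a number lying between those of compound 1 and compound 2 is expected. Compound 3 is therefore estimated at 120 nM, with a range from 35 nM to 450 nM, meaning an expected step of a 2.4-fold lower number from compound 2 to compound 3 (0.37 log units; beyond the scatter).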

Compound 3, half-maximal inhibitory concentration: 137 nM
Estimate against measurement, compound 3: 1.1-fold (0.06 log units) below; the measured number falls inside the stated range.
By their numbers in this assay, from the lowest: compound 1; then compound 3; then compound 2.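

In this assay, moving the chlorine, with no atom gained or lost, from 3-chloro-1H-indazol-5-yl to 6-chloro-1H-indazol-5-yl gives a 2.1-fold lower number from compound 2 to compound 3 (0.32 log units; beyond the scatter) and so shows that the number at this place responds to where the chlorine stands, not only to which atoms the group holds. The 4-methyl-1H-indazol-5-yl group still keeps the lowest number of the three, since replacing it with 6-chloro-1H-indazol-5-yl gives a 2.7-fold higher number from compound 1 to compound 3 (0.44 log units; beyond the scatter) and so the better of the two chlorine placements shown does not match it. Nothing measured here accounts for either step, so these results describe the change in the number without explaining it.

Compound 1 and compound 3 differ in both the group and its position on the indazole, so the compounds shown cannot separate the effect of methyl against chlorine from that of position. As far as these compounds go, it also remains open how a fluorine atom, a methoxy group or a nitrile would fare in place of this chlorine, and where the plain 1H-indazol-5-yl group, with neither chlorine nor methyl, would stand against these three.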